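Anilino to benzylamino swap on the shared core

The compounds below may be only part of what the source reports. "The series", "measured", "known", "first", "only" and "open" are said of these compounds alone.

Two compounds on the shared core have numbers in an assay on COS-7 cells for agonist activity at Free fatty acid receptor 1 (Homo sapiens), read by scintillation counting and inositol phosphate accumulation, with a stated time of 90 min; on this read-out higher numbers stand for an effect only at larger amounts of compound and lower numbers for an effect already at smaller amounts. Compound 1 `Cc1ccc(Nc2nc(N)nc(COc3ccc4c(C)cc(=O)oc4c3)n2)cc1Cl` gives 140 nM, the lowest of the two numbers. Compound 2 `Cc1cc(Nc2nc(N)nc(COc3ccc4c(C)cc(=O)oc4c3)n2)ccc1Cl` gives 240 nM; the step of a 1.7-fold higher number from compound 1 to compound 2 (0.23 log units; within the scatter) stays within the scatter, so the two cannot be ordered. Compound 3 `Cc1cc(=O)oc2cc(OCc3nc(N)nc(NCc4ccc(F)cc4)n3)ccc12` is not yet measured. It differs from compound 1 by 4-fluorobenzyl in place of 3-chloro-4-methylphenyl on a nitrogen on an aromatic ring. Going by the values given here, the single measured step only exchanges one substitution pattern of the phenyl on that nitrogen for another and keeps the ring directly attached; it does not cover an added methylene or the loss of chlorine and methyl for fluorine, so it bears on the new step only loosely and gives no direction of its own. On this thin basis a moderate rise in the number is expected, with wide uncertainty. Compound 3 is estimated at 500 nM, within 150 nM to 2000 nM. This estimate amounts to an expected 3.6-fold higher number from compound 1 to compound 3 (0.55 log units; beyond the scatter).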

Compound 3, half-maximal effective concentration: 7820 nM
Compound 3: the middle estimate sits 16-fold (1.19 log units) below what was measured; measured number outside the range, above it.
By their numbers in this assay, from the lowest: compounds 1 and 2 (each within the scatter of the next); then compound 3.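

In this assay, the nitrogen on an aromatic ring shows no readable difference between the two chloro-methylphenyl patterns, as a 1.7-fold higher number from compound 1 to compound 2 (0.23 log units; within the scatter) shows, whereas 4-fluorobenzyl at the same place gives a 56-fold higher number from compound 1 to compound 3 (1.75 log units; beyond the scatter) and a 33-fold higher number from compound 2 to compound 3 (1.51 log units; beyond the scatter). The groups that leave and enter are equal in heavy atoms, yet the swap changes both the link from ring to nitrogen and the ring's substituents, so the step belongs to the swap as a whole and cannot be divided between the two changes. No measurement at hand offers an explanation for the size of this step.

Still open, from the compounds shown here alone, is whether the benzyl link or the loss of chlorine and methyl for fluorine carries the step, a question that 4-fluorophenyl or 3-chloro-4-methylbenzyl on this nitrogen would separate. Also open, going by these compounds, is how a longer chain, such as 2-phenylethyl, would read at this place.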